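The source may report more compounds than this note shows. Statements on the series, on what has been measured and on what is new or still open speak of the compounds shown alone.

Measured so far:
Compound 1 `CCC/N=C1\S/C(=C\c2ccc(O)c(Cl)c2)C(=O)N1C1CCS(=O)(=O)CC1` gives 75000 nM.
Compound 2 `Cc1ccccc1N1C(=O)/C(=C/c2ccc(O)c(Cl)c2)S/C1=N\CCO` gives only a limit, > 250000 nM.

Both were tested in a physicochemical assay for solubility, measured as kinetic solubility; on this read-out lower numbers stand for lower solubility and higher numbers for higher solubility. Among the compounds with values here, compound 1 is the one compound with an actual number in this assay, since the other entry is a limit rather than a measured value: the limit of > 250000 nM in this assay, at which 1 of the 2 values shown sits. So compound 1 stands as the single fixed point from which any comparison must start, and nothing in these two results says how the two compounds relate beyond the fact that compound 2 sits at the limit.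

The next compound, compound 3 `CCC/N=C1\S/C(=C\c2ccc(O)c(Cl)c2)C(=O)N1C(C)C`, keeps the shared core of compound 1 and changes one group: isopropyl in place of 1,1-dioxothian-4-yl on an amide-type nitrogen in a ring. Within the data shown here, no pair of measured compounds differs in this single place, so there is no measured step to lean on. The expectation is that the step from compound 1 to compound 3 in this assay will be downward, somewhat beyond the usual scatter, estimated as a 3.8-fold lower number from compound 1 to compound 3 (0.57 log units; beyond the scatter). For compound 3 the estimated solubility in this assay is 20000 nM, expected to fall between 5000 nM and 80000 nM.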

Compound 3, solubility: 20000 nM
Beside the measured number, compound 3's estimate shows no gap at the digits printed; the range from low to high includes it.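

In this assay, within the data shown here, compound 3 supplies the first real step at this position, the amide-type nitrogen in a ring, and the step reads a 3.8-fold lower number from compound 1 to compound 3 (0.57 log units; beyond the scatter). Among these compounds, until now the only other number came with a limit that allowed no comparison. It shows that this position is not silent: swapping 1,1-dioxothian-4-yl for isopropyl moves the number beyond the usual scatter, although the change is a large one in which the ring, the hydrogen-bond acceptors and most of the group's size all leave together. Nothing shown gives a measured reason for this step, so it stands as an observation and not as an explanation.

The compounds shown leave open which part of the departing group matters, and a cyclohexyl group, which keeps a six-membered ring but lacks the sulfur and its oxygens, would begin to separate these parts. Also open, on these data alone, is whether the step keeps its size when a longer chain replaces the propyl group elsewhere on the shared core.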